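A few compounds are considered here, and "the series" means these few. Any claim that something is new, unique, unknown or untested is made for them only; others in the source may bear on it.

Of the compounds shown here, three have been measured. Compound 1 `O=S(=O)(NCCNC(=S)Nc1cc(C(F)(F)F)cc(C(F)(F)F)c1)c1ccc(-c2ccccc2OCc2cccc(O)c2)s1` gives 14900 nM in a functional assay on HeLa cells (Homo sapiens) for inhibition, read by CCK-8 assay, with a stated time of 48 h; a lower number here means a stronger inhibitor, a higher number a weaker inhibitor. Compound 2 `O=S(=O)(NCCNC(=S)Nc1cc(C(F)(F)F)cc(C(F)(F)F)c1)c1ccc(-c2ccccc2OCc2ccccc2)s1` gives 4700 nM in this assay. Compound 3 `O=[N+]([O-])c1cccc(NC(=S)NCCNS(=O)(=O)c2ccc(-c3ccccc3OCc3ccccc3)s2)c1` gives 12800 nM in this assay.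

The change hydroxy in place of hydrogen on an aromatic carbon made the step of a 3.2-fold higher number from compound 2 to compound 1 (0.50 log units; beyond the scatter). The difference between the core of compound 2 and the core of compound 3 is not broken down here; their values in this assay differ beyond the scatter, with compound 3 giving the higher number.

Compound 4 `O=[N+]([O-])c1cccc(NC(=S)NCCNS(=O)(=O)c2ccc(-c3ccccc3OCc3cccc(O)c3)s2)c1` differs from compound 3 by hydroxy in place of hydrogen on an aromatic carbon, the same change as from compound 2 to compound 1. Among the compounds with values here, the step of a 3.2-fold higher number from compound 2 to compound 1 (0.50 log units; beyond the scatter) is the only earlier measurement of this change. A step of similar size, a 3.0-fold higher number from compound 3 to compound 4 (0.47 log units; beyond the scatter), is expected on that basis. For compound 4 an estimated 38000 nM is expected in this assay, between 14000 nM and 100000 nM.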

Compound 4, half-maximal inhibitory concentration: 11100 nM
For compound 4 the middle estimate is 3.4-fold (0.53 log units) above the measured one, and the stated range ends above it.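

In this assay, within the data shown here, the change from phenyl to 3-hydroxyphenyl gives a 1.2-fold lower number from compound 3 to compound 4 (0.06 log units; within the scatter) on the core of compound 3 and so leaves no step that can be told from the scatter, unlike the clear step on the core of compound 2. The two steps therefore do not agree: the same change on two cores in this assay, a 3.2-fold higher number (0.50 log units; beyond the scatter) from compound 2 to compound 1 and a 1.2-fold lower number (0.06 log units; within the scatter) from compound 3 to compound 4, 3.7-fold (0.56 log units) apart, beyond the scatter of two such steps. This shows that the step seen on one core did not carry over to the other in these two pairs, but two pairs do not show which feature of the cores accounts for the gap, or what the change would do on a further core.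

As far as these compounds go, it remains open how a methoxy group or an amine in place of the hydroxy would behave on these two cores. A third core carrying the same change would be needed to show which of the two steps is the more typical.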